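Cytotoxicity notes on the series: step to compound 4

The source may hold more compounds than are shown below. What is called first, only, known or untested is meant among the compounds shown, and "the series" means these compounds.

Measured so far in a toxicity assay on NIH3T3 cells (Mus musculus) for cytotoxicity, read by resazurin assay; on this read-out higher numbers stand for an effect only at larger amounts of compound and lower numbers for an effect already at smaller amounts:
- compound 1, `COC(=O)c1ccc(NCc2cncn2Cc2ccc(C#N)cc2)cc1-c1ccccc1`: compound 1 gives > 10000 nM, a limit of the assay.
- compound 2, `COC(=O)c1ccc(NCc2cncn2Cc2ccc(Cl)cc2)cc1-c1ccccc1`: compound 2 gives 25000 nM.
- compound 3, `COC(=O)c1ccc(NCc2cncn2Cc2ccc(F)cc2F)cc1-c1ccccc1`: compound 3 gives > 1000 nM, a limit of the assay.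

Compound 3 stands only as a limit in this assay, and of the three values shown, one other is also a limit. The steps between the measured compounds cannot be sized: a step that the limit leaves unreadable from compound 1 to compound 2, a step that the two limits leave unreadable from compound 1 to compound 3 and a step that the limit leaves unreadable from compound 2 to compound 3 all run into limits, as the limit of > 1000 nM in this assay, at which 1 of the 3 values shown sits, and the limit of > 10000 nM in this assay, at which 1 of the 3 values shown sits, show.

Compound 4, `COC(=O)c1ccc(NCc2cncn2Cc2ccc(-c3ccccc3)cc2)cc1-c1ccccc1`, differs from compound 3 at one place: 4-phenylphenyl in place of 2,4-difluorophenyl on a saturated chain carbon bound to an aromatic nitrogen. Among the compounds with values here, the steps that bear on this place are those from compound 1 to compound 3 and from compound 2 to compound 3, both unreadable, so no direction or size can be taken from them. Within the data shown here, the only numeric value, that of compound 2, sits high in this assay, and compound 1 also sits at a high limit.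

Compound 4 is therefore expected to sit at a similarly high value in this assay, with a step that the limit leaves unreadable from compound 3 to compound 4 expected as the step from the limit of compound 3. The estimate for compound 4 is 20000 nM, with a range from 4000 nM to 80000 nM, and a fair chance that only a limit is reported.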

Compound 4, half-maximal effective concentration: > 1000 nM
Compound 4 ended at the assay's limit; the forecaster's own chance of this, stated with the estimate: 50%; the middle value is on the limit's open side.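

In this assay compound 4 gives > 1000 nM, a limit of the assay, so the steps joining compound 4 to compound 1, compound 2 and compound 3 cannot be read: the limit of > 1000 nM in this assay, at which 2 of the 4 values shown sit.

The compounds shown leave open whether exchanging 2,4-difluorophenyl for 4-phenylphenyl changes cytotoxicity at all, and by how much.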